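A 3-methoxyphenyl group in place of 4-bromophenyl

The compounds below may be only part of what the source reports. "The series", "measured", "known", "first", "only" and "open" are said of these compounds alone.

In an ADME assay on SH-SY5Y cells (Homo sapiens) for cytotoxicity, read by MTT assay, with a stated time of 72 h (a lower number here means a stronger inhibitor, a higher number a weaker inhibitor), compound 3 `O=C(CN1CCN(C(=O)c2ccc(Br)cc2)CC1)N1CCN(CCCc2c[nH]c3ccc(F)cc23)CC1` gives a number (47400 nM) level, within the scatter, with that of compound 1 `O=C(CN1CCN(C(=O)c2ccc(Br)cc2)CC1)N1CCN(CCCc2c[nH]c3ccccc23)CC1` (59300 nM). Both numbers lie under that of compound 2 `O=C(CN1CCN(C(=O)c2cccc(Cl)c2)CC1)N1CCN(CCCc2c[nH]c3ccccc23)CC1` (120000 nM). Compound 4 `COc1cccc(C(=O)N2CCN(CC(=O)N3CCN(CCCc4c[nH]c5ccc(F)cc45)CC3)CC2)c1` differs from compound 3 by 3-methoxyphenyl in place of 4-bromophenyl on a carbonyl carbon. The closest measured precedent is a 2.0-fold higher number from compound 1 to compound 2 (0.31 log units; beyond the scatter), which also replaces 4-bromophenyl, there with 3-chlorophenyl. The fluoro step, a 1.3-fold lower number from compound 1 to compound 3 (0.10 log units; within the scatter), is at a different place and stays within the scatter. Within the data shown here, no measured compound carries a methoxy group. A modest rise of similar size is therefore expected, a 1.9-fold higher number from compound 3 to compound 4 (0.28 log units; within the scatter). Compound 4 is estimated at 90000 nM, with an expected range of 45000 nM to 170000 nM.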

Compound 4, half-maximal inhibitory concentration: 79400 nM
For compound 4 the middle estimate is 1.1-fold (0.05 log units) above the measured one, within the range that was stated.
By their numbers in this assay, from the lowest: compounds 3, 1, 4 and 2 (each within the scatter of the next, the first and the last beyond it).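

In this assay, 3-methoxyphenyl in place of 4-bromophenyl on a carbonyl carbon gives a 1.7-fold higher number from compound 3 to compound 4 (0.22 log units; within the scatter), so this exchange, which brings in one hydrogen-bond acceptor, cannot be told from the scatter. The earlier exchange at this place, to 3-chlorophenyl without the fluoro group, gave a 2.0-fold higher number from compound 1 to compound 2 (0.31 log units; beyond the scatter), so not every replacement of 4-bromophenyl here stays within the scatter. Nothing given here accounts for this result.

Going by these compounds, whether 3-methoxyphenyl behaves alike without the fluoro group remains open. So does the outcome for an aromatic ring carrying an amine or a carboxylic acid at this place.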